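Removing the methyl from compound 2's benzyl group

This account rests on a few compounds, and the source may have more. Where it says the series, first, only, none or still open, it means among the compounds named here.

Measured so far:
- compound 1 `CCOC(=O)[C@H]1CC[C@H](CNC(=O)c2ccc(Cc3cc4c(cc3C)C(C)(C)CCC4(C)C)o2)CC1`: 2730 nM
- compound 2 `Cc1ccc(CNC(=O)c2ccc(Cc3cc4c(cc3C)C(C)(C)CCC4(C)C)o2)cc1`: 60 nM

Both compounds share the same core and were tested in an assay on isolated protein for binding affinity to Gonadotropin-releasing hormone receptor (Rattus norvegicus); on this read-out lower numbers stand for stronger inhibition and higher numbers for weaker inhibition. Among the compounds with values here, compound 1 gives 2730 nM, while compound 2 gives 60 nM, the lowest of the two numbers; the only step, a 46-fold lower number from compound 1 to compound 2 (1.66 log units; beyond the scatter), is large and exchanges the whole group on the saturated chain carbon bound to the amide-type nitrogen.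

Compound 3 `Cc1cc2c(cc1Cc1ccc(C(=O)NCc3ccccc3)o1)C(C)(C)CCC2(C)C` differs from compound 2 by a smaller change: hydrogen in place of methyl on an aromatic carbon, para to a large group. Within the data shown here, no measured step touches this position, so the single step from compound 1 to compound 2, which swaps an entire ring, offers no direct guidance. A change of one carbon on the outer edge of the benzyl group is expected to move the number little, possibly a modest rise, with a 1.7-fold higher number from compound 2 to compound 3 (0.22 log units; within the scatter) as the estimated step. Compound 3 is therefore estimated at 100 nM, within 35 nM to 300 nM.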

Compound 3, inhibition constant: 240 nM
Compound 3: the middle estimate sits 2.4-fold (0.38 log units) below what was measured; the range from low to high includes it.
By their numbers in this assay, from the lowest: compound 2; then compound 3; then compound 1.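

In this assay, one methyl group on the aromatic ring makes a measurable difference: replacing it with hydrogen gives a 4.0-fold higher number from compound 2 to compound 3 (0.60 log units; beyond the scatter), so 4-methylbenzyl and benzyl cannot be treated as equivalent at this position. Even without the methyl, the benzyl group keeps the larger part of the advantage over the 4-(ethoxycarbonyl)cyclohexyl group, with an 11-fold lower number from compound 1 to compound 3 (1.06 log units; beyond the scatter); the change of ring therefore accounts for more of the difference between compound 1 and compound 2 than the methyl does. No measurement shown here explains why the methyl lowers the number.

On these data alone, the three compounds show only methyl and hydrogen on this aromatic carbon, so it remains open whether a longer chain such as ethyl, or a chlorine atom or a methoxy group, would give a lower or higher number than methyl. It is also unknown whether the same exchange of methyl for hydrogen would produce a step of similar size on a different core, or whether a methyl group on another carbon of the ring would matter as much.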